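The compounds below may be only part of what the source reports. "The series", "measured", "known", "first", "only" and "open" are said of these compounds alone.

Measured compounds:
Compound 1 `Cc1ccc(OCC(=O)N(Cc2cccs2)C2COC2)cc1` gives 23000 nM in an assay on HEK293 cells for agonist activity at transient receptor potential cation channel subfamily M member 8 (Homo sapiens), read by fluorescence and calcium flux, with a stated time of 15 min; on this read-out lower numbers stand for an effect already at smaller amounts and higher numbers for an effect only at larger amounts of compound.
Compound 2 `CCN1C(=O)C(Oc2ccc(C)cc2)C1c1cccs1` is reported in this assay as "active" (no number reported), with no number given.
Compound 3 `CCN(Cc1cccs1)C(=O)CCc1ccc(C)cc1` gives 93 nM in this assay.

Compound 1 therefore stands at the highest of the two numbers shown, and compound 3 lies at a far lower number, a gap well beyond the usual scatter. Compound 4 `Cc1ccc(OCC(=O)N(CCO)Cc2cccs2)cc1` has not yet been measured. It differs from compound 1 in one place: 2-hydroxyethyl in place of oxetan-3-yl on an amide-type nitrogen. No pair of measured compounds shows what this swap does, so there is no shown step to lean on. The change is small, and the expected step is a 1.5-fold lower number from compound 1 to compound 4 (0.19 log units; within the scatter), a slight move toward a lower number, hardly beyond the scatter. Compound 4 is estimated at 15000 nM, within 4000 nM to 60000 nM.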

Compound 4, half-maximal effective concentration: 900 nM
Compound 4: middle estimate off by 17-fold (1.22 log units), on the high side; the whole stated range lies above it.
By their numbers in this assay, from the lowest: compound 3; then compound 4; then compound 1.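

The group on this amide-type nitrogen has a large effect: in this assay, placing 2-hydroxyethyl there instead of oxetan-3-yl gives a 26-fold lower number from compound 1 to compound 4 (1.41 log units; beyond the scatter). This swap removes the four-membered ring and adds a hydrogen-bond donor in a single change, so this pair cannot show which of the two goes with the step. No measurement here explains the step. Open, from the compounds shown here alone, is whether a 2-methoxyethyl group, which has an ether oxygen in place of the hydroxyl, would keep the lower number. A longer chain such as 3-hydroxypropyl or an amine such as 2-aminoethyl also remains to be compared at this position.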